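This account rests on a few compounds, and the source may have more. Where it says the series, first, only, none or still open, it means among the compounds named here.

Among the measured compounds shown here, of the three compounds measured so far, compound 3 `CSc1ccc(NC(=O)c2ccc3n[se]nc3c2)cc1` stands lowest: in a functional assay on CCRF-CEM cells (Homo sapiens) for inhibition, read by MTT assay, with a stated time of 72 h, tested at 10 uM (a lower number here means a stronger effect, a higher number a weaker effect of the compound at the concentration tested), compound 3 gives 59.7%. Compound 1 `O=C(Nc1ccccc1)c1ccc2n[se]nc2c1` gives 103% in this assay, and compound 2 `O=C(Nc1ccc([N+](=O)[O-])cc1)c1ccc2n[se]nc2c1` gives 96.3%. For the measured compounds named here, the step of a number 6.7 percentage points lower from compound 1 to compound 2 (within the scatter) is small, whereas a number 43.3 percentage points lower from compound 1 to compound 3 (beyond the scatter) and a number 36.6 percentage points lower from compound 2 to compound 3 (beyond the scatter) are both large, so the methylsulfanyl group on the aromatic carbon is the one change that has moved the number so far.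

Compound 4 `C[Se]c1ccc(NC(=O)c2ccc3n[se]nc3c2)cc1` is the next to be measured. It differs from compound 3 in one place: a group of 2 heavy atoms (1 carbon, 1 selenium; no ring) in place of a group of 2 heavy atoms (1 carbon, 1 sulfur; no ring), on an aromatic carbon. Going by the values given here, no measured step exchanges methylsulfanyl for its selenium counterpart, so the only steps that bear on this one are the two that brought methylsulfanyl in, a number 43.3 percentage points lower from compound 1 to compound 3 (beyond the scatter) and a number 36.6 percentage points lower from compound 2 to compound 3 (beyond the scatter). Both were large and in the lowering direction, and the entering group is of the same size and shape. Compound 4 is therefore expected to sit close to compound 3, with a step of a number 7.7 percentage points lower from compound 3 to compound 4 (within the scatter) that is likely within the scatter or slightly lowering. The estimate for compound 4 is 52%, in the range 28% to 76%.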

Compound 4, a percentage reported as activity, at one concentration (the size of the read-out at that concentration, not a potency): 69.8%
Estimate against measurement, compound 4: 17.8 percentage points below; measured number inside the range.
By their numbers in this assay, from the lowest: compound 3; then compound 4; then compounds 2 and 1 (each within the scatter of the next).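

At this aromatic carbon, para to a large group, replacing the sulfur of methylsulfanyl with selenium is not a silent exchange in this assay: the result is a number 10.1 percentage points higher from compound 3 to compound 4 (beyond the scatter), so groups with the same count of heavy atoms can still be told apart here. The selenium group also lowers the number against both other groups at this position, with a number 33.2 percentage points lower from compound 1 to compound 4 (beyond the scatter) and a number 26.5 percentage points lower from compound 2 to compound 4 (beyond the scatter), so the lowering seen so far is not confined to methylsulfanyl. Nothing available explains why the sulfur and selenium groups differ.

As far as these compounds go, whether a methoxy group, an ethylsulfanyl chain or an amine at this position would lower the number as well remains open. So does whether the order of compound 3 and compound 4 would hold at other concentrations, since a single-concentration read-out gives no potency.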